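Removing the Chloro Group: Plasma Protein Binding Expected

A few compounds are considered here, and "the series" means these few. Any claim that something is new, unique, unknown or untested is made for them only; others in the source may bear on it.

Three compounds sharing one core were measured in an ADME assay on a cell-free system (plasma, Mus musculus) for protein binding, using equilibrium dialysis. Compound 1 `CC(C)c1csc(-c2cccc(CN(C)c3ccc4[nH]nc(C(=O)O)c4c3)c2O)n1` gives a value that is a limit of the assay rather than a number, > 99.9%. Compound 2 `Cc1nc(-c2cccc(CNc3ccc4[nH]nc(C(=O)O)c4c3)c2O)sc1C` likewise gives only a limit in this assay, > 99.8%. For the measured compounds named here, compound 3 `CN(C)c1noc(-c2cccc(CNc3ccc4[nH]nc(C(=O)O)c4c3)c2Cl)n1` stands apart as the only one of the three with an actual number in this assay, 99.4%; the two remaining values rest on the limit of > 99.8% in this assay, at which 1 of the 3 values shown sits, and (the limit of > 99.9% in this assay, at which 1 of the 3 values shown sits), so no step between measured compounds can be read off.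

Compound 4 `CN(C)c1noc(-c2cccc(CNc3ccc4[nH]nc(C(=O)O)c4c3)c2)n1` has not yet been measured in this assay. It differs from compound 3 by hydrogen in place of chloro on an aromatic carbon. Going by the values given here, since no measured pair gives the size of such a change, the expectation rests on compound 3 alone, at 99.4%. The step a 1.7-fold higher unbound fraction from compound 3 to compound 4 (0.22 log units; within the scatter) is expected to be small and, if anything, downward, within or only just beyond the usual scatter. Compound 4 is therefore estimated to give 99% in this assay, with a range from 97.8% to 99.6%.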

Compound 4, plasma protein binding in the Mus musculus assay: 99%
For compound 4 middle estimate and measured number coincide at the digits printed, within the range that was stated.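

For the compounds shown here, in the Mus musculus assay, hydrogen in place of chloro on an aromatic carbon, ortho to a 3-(dimethylamino)-1,2,4-oxadiazol-5-yl group, gives the first step that can be read: a 1.7-fold higher unbound fraction from compound 3 to compound 4 (0.22 log units; within the scatter). In a physicochemical assay for solubility, measured as kinetic solubility, at pH 2 (on this read-out lower numbers stand for lower solubility and higher numbers for higher solubility), compound 3 gives 7000 nM and compound 4 gives 308000 nM. The same change thus gives in the physicochemical assay a 44-fold higher number from compound 3 to compound 4 (1.64 log units; beyond the scatter), a step beyond the scatter, whereas its step in the Mus musculus assay lies within the scatter.

Compound 1 and compound 2 give only limits in the Mus musculus assay, so steps to them cannot be read. This single pair also leaves open how plasma protein binding and the physicochemical assay would respond to a methoxy group or an amine at this position.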